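The source may hold more compounds than are shown below. What is called first, only, known or untested is meant among the compounds shown, and "the series" means these compounds.

In an assay on CHO cells for displacement of a labelled ligand from prostaglandin D2 receptor 2 (Homo sapiens), read by scintillation counting (on this read-out higher numbers stand for weaker inhibition and lower numbers for stronger inhibition), three compounds have been measured so far:

compound 1, `CCCc1ccncc1C#Cc1cc(Cl)ccc1OCC(=O)O`: 4.3 nM
compound 2, `CN(c1cccc(C#Cc2cc(Cl)ccc2OCC(=O)O)c1)S(C)(=O)=O`: 122 nM
compound 3, `CCCS(=O)(=O)c1ccc(F)c(C#Cc2cc(Cl)ccc2OC(C)C(=O)O)c1`: 3 nM

Compound 1 holds the second highest of these three numbers. Its nearest neighbour is compound 3, whose number lies within the usual scatter of that of compound 1, so no order between the two can be read. Compound 2 stands well above both, beyond the scatter. The next compound, compound 4, `O=C(O)COc1ccc(Cl)cc1C#Cc1cccnc1`, is not yet measured in this assay. It differs from compound 1 in one place: hydrogen in place of propyl on an aromatic carbon. Going by the values given here, no step between measured compounds covers such a change, so the data offer no direct guide. Compound 4 is nonetheless expected to show a higher number, with an estimated step of a 7.0-fold higher number from compound 1 to compound 4 (0.84 log units; beyond the scatter). Compound 4 is estimated at 30 nM, in a range from 8 nM to 120 nM.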

Compound 4, inhibition constant: 117 nM
Estimate against measurement, compound 4: 3.9-fold (0.59 log units) below, within the range that was stated.
By their numbers in this assay, from the lowest: compounds 3 and 1 (each within the scatter of the next); then compounds 4 and 2 (each within the scatter of the next).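

In this assay, putting hydrogen in place of propyl on this aromatic carbon, opposite the ring nitrogen, gives a 27-fold higher number from compound 1 to compound 4 (1.43 log units; beyond the scatter), a large step beyond the scatter. This position is therefore far from indifferent in this series, and the propyl group accounts for much of the strength of binding seen with the shared core. Nothing available explains why the step is this large.

As far as these compounds go, whether methyl or ethyl would retain part of this gain remains open. So does whether a longer chain such as butyl, a cyclopropyl ring or an amine at this carbon would match or exceed propyl.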